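The source may report more compounds than this note shows. Statements on the series, on what has been measured and on what is new or still open speak of the compounds shown alone.

Measured in a functional assay on K562 cells (Homo sapiens) for antiproliferative activity; a higher number here means a weaker inhibitor of growth, a lower number a stronger inhibitor of growth:
- compound 1 `COCCCCCCCCCCCCCCC/C=C1\CC(CO)(COC(=O)C(C)(C)C)OC1=O`: 0.189 ug/mL
- compound 2 `CCCCCCCCC(O)CCCCCC/C=C1\CC(CO)(COC(=O)C(C)(C)C)OC1=O`: 7.3 ug/mL

Compound 2 has the higher number of the two, so it is the weaker growth inhibitor. Compound 3 `CCCCCOCCCCCCC/C=C1\CC(CO)(COC(=O)C(C)(C)C)OC1=O` differs from it as follows: (pentyloxy)methyl in place of 1-hydroxynonyl on a saturated chain carbon, six bonds along the chain from a double-bonded chain carbon. Within the data shown here, one measured step bears on this change: a 39-fold higher number from compound 1 to compound 2 (1.59 log units; beyond the scatter). That large step, beyond the scatter, brought in the same 1-hydroxynonyl that now leaves. The entering (pentyloxy)methyl is not the 9-methoxynonyl of compound 1, so only a partial return is expected in this assay. The expected change is a 12-fold lower number from compound 2 to compound 3 (1.09 log units; beyond the scatter). For compound 3, the estimated value is 0.6 ug/mL, within a range from 0.15 ug/mL to 3 ug/mL.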

Compound 3, concentration for 50% growth inhibition: 1.15 ug/mL
Compound 3: middle estimate off by 1.9-fold (0.28 log units), on the low side; the measured number falls inside the stated range.
By their numbers in this assay, from the lowest: compound 1; then compound 3; then compound 2.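

Swapping 1-hydroxynonyl for (pentyloxy)methyl recovers part of the growth inhibition in this assay (a 6.3-fold lower number from compound 2 to compound 3 (0.80 log units; beyond the scatter)), so activity at this position does not depend on the 9-methoxynonyl of compound 1 alone. The recovery is only partial (a 6.1-fold higher number from compound 1 to compound 3 (0.78 log units; beyond the scatter)), which shows that two chains carrying an ether oxygen can still differ clearly. No measurement given here explains either shift. The compounds leave open whether the place of the oxygen or the length of the chain end separates compound 1 from compound 3. They also leave open how an amine or a carboxylic acid would compare here.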